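The source may hold more compounds than are shown below. What is called first, only, known or untested is meant among the compounds shown, and "the series" means these compounds.

Compound 2 `N#Cc1cccc([C@]23CCC(N(CCN4CC[C@@H](O)C4)C(=O)Nc4cccc([N+](=O)[O-])c4)CC2C3)c1` carries a 3-nitrophenyl group on the urea nitrogen of the shared core. In a functional assay for antagonist activity at melanin-concentrating hormone receptor 1 (Homo sapiens) (on this read-out higher numbers stand for weaker inhibition and lower numbers for stronger inhibition), compound 2 gives 60 nM, the highest of the three numbers recorded so far. Compound 1 `N#Cc1cccc([C@]23CCC(N(CCN4CC[C@@H](O)C4)C(=O)Nc4cc(F)cc(F)c4)CC2C3)c1`, with a 3,5-difluorophenyl group in that place, gives 15 nM, and the step of a 4.0-fold higher number from compound 1 to compound 2 (0.60 log units; beyond the scatter). Compound 3 `N#Cc1cccc([C@]23CCC(N(CCN4CC[C@@H](O)C4)C(=O)Nc4cccc(Br)c4)CC2C3)c1`, bearing a 3-bromophenyl group, gives 34 nM; the step of a 2.3-fold higher number from compound 1 to compound 3 (0.36 log units; beyond the scatter), while the step of a 1.8-fold lower number from compound 2 to compound 3 (0.25 log units; within the scatter).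

Compound 4 `N#Cc1cccc([C@]23CCC(N(CCN4CC[C@@H](O)C4)C(=O)Nc4cccc(Cl)c4)CC2C3)c1` has not yet been measured. It differs from compound 2 by chloro in place of nitro on an aromatic carbon. The step that bears most directly on this change is the one from nitro to bromo, where a 1.8-fold lower number from compound 2 to compound 3 (0.25 log units; within the scatter); chloro, like bromo, is a single halogen atom, so a step of comparable size is the natural expectation. The exchange of one substituent on the urea-borne phenyl ring has so far produced only modest movements in this assay, as a 2.3-fold higher number from compound 1 to compound 3 (0.36 log units; beyond the scatter) and a 4.0-fold higher number from compound 1 to compound 2 (0.60 log units; beyond the scatter) show.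

Compound 4 is therefore expected to give 35 nM in this assay, within a range from 15 nM to 80 nM, which means an expected step of a 1.7-fold lower number from compound 2 to compound 4 (0.23 log units; within the scatter), a change not clearly beyond the scatter.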

Compound 4, inhibition constant: 27 nM
The estimate for compound 4 lay 1.3-fold (0.11 log units) above the measured number; measured number inside the range.
By their numbers in this assay, from the lowest: compounds 1, 4, 3 and 2 (each within the scatter of the next, the first and the last beyond it).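

In this assay the step of a 2.2-fold lower number from compound 2 to compound 4 (0.35 log units; beyond the scatter) lies beyond the scatter, so the exchange of nitro for chloro at this position gives a clear separation, which the exchange for bromo in compound 3 did not. Chloro and bromo cannot be told apart, with the step of a 1.3-fold lower number from compound 3 to compound 4 (0.10 log units; within the scatter) inside the scatter, and the step of a 1.8-fold higher number from compound 1 to compound 4 (0.26 log units; within the scatter) also stays inside it, so the single chloro, unlike the bromo of compound 3, is not separated from the 3,5-difluorophenyl group. Nothing available accounts for these differences.

The single substituents shown on this ring are nitro, bromo and chloro, which leaves open whether fluoro, methoxy, an amine or a carboxylic acid on that aromatic carbon would give numbers close to those of the two halogens or close to that of nitro. From the compounds shown here alone, it also remains open whether the separation between chloro and nitro would persist if another part of the shared core were changed, for example with a longer chain in place of the ethyl link on the urea nitrogen.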